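The source may report more compounds than this note shows. Statements on the series, on what has been measured and on what is new or still open speak of the compounds shown alone.

Measured in a functional assay on A549 cells (Homo sapiens) for inhibition, read by sulforhodamine B assay, with a stated time of 48 h; a higher number here means a weaker inhibitor, a lower number a stronger inhibitor:
compound 1 `CCOC(=O)CCO/N=C(/c1ccc(OC)c(OC)c1OC)c1cccc2ccccc12` gives 19600 nM
compound 2 `COc1ccc(C(O)(Cc2ccc(F)cc2)c2cccc3ccccc23)c(OC)c1OC` gives 5940 nM
compound 3 `COc1ccc(/C(=N/OC(C)=O)c2cccc3ccccc23)c(OC)c1OC` gives 17200 nM

Compound 3 stands second highest of the three numbers. Compound 1 lies nearest, within the scatter, so no order between them is claimed; compound 2 lies furthest, with a lower number beyond the scatter.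

Compound 4 `COc1ccc(/C(=N/O)c2cccc3ccccc23)c(OC)c1OC` differs from compound 3 in one place: hydrogen in place of acetyl on an oxygen. For the measured compounds named here, the only measured step that bears on this site is a 1.1-fold lower number from compound 1 to compound 3 (0.06 log units; within the scatter), an exchange of the group on the same oxygen that stayed within the scatter. Going by the values given here, nothing among the measured compounds shows that group's removal altogether, so the expectation rests on that single step. No step beyond the scatter is therefore expected in this assay for compound 4, and the estimate is 15000 nM with a range 6000 nM to 40000 nM, meaning a 1.1-fold lower number from compound 3 to compound 4 (0.06 log units; within the scatter).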

Compound 4, half-maximal inhibitory concentration: 13100 nM
For compound 4 the middle estimate is 1.1-fold (0.06 log units) above the measured one; measured number inside the range.
By their numbers in this assay, from the lowest: compound 2; then compounds 4, 3 and 1 (each within the scatter of the next).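

In this assay, a 1.3-fold lower number from compound 3 to compound 4 (0.12 log units; within the scatter) shows that removing acetyl from this oxygen altogether, leaving hydrogen, stays within the scatter. With a 1.5-fold lower number from compound 1 to compound 4 (0.17 log units; within the scatter) also within the scatter, hydrogen, acetyl and 2-(ethoxycarbonyl)ethyl on this oxygen cannot be ranked in this assay. No available evidence bears on this result.

Still open, as far as these compounds go, is whether a chain ending in a carboxylic acid or an amine on this oxygen would give a step beyond the scatter. A benzyl group at the same place also remains untested in the compounds shown.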